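Shifting the styryl ring of a chromene chalcone series

This account rests on a few compounds, and the source may have more. Where it says the series, first, only, none or still open, it means among the compounds named here.

Compound 2 `COc1ccc(C(=O)/C=C/c2ccc(N(C)C)cc2)c2c1C=CC(C)(C)O2` carries a 4-(dimethylamino)phenyl group on the double-bonded chain carbon. In a functional assay on SK-OV-3 cells (Homo sapiens) for antiproliferative activity, read by MTT assay, with a stated time of 24 h (on this read-out higher numbers stand for weaker inhibition and lower numbers for stronger inhibition), compound 2 gives 2750 nM, the lowest of the two numbers recorded. Compound 1 `COc1ccc(C(=O)/C=C/c2cc(OC)c(OC)c(OC)c2)c2c1C=CC(C)(C)O2`, with a trimethoxyphenyl group in that place, gives 9700 nM in this assay. Compound 3 `COc1ccc(C(=O)/C=C/c2ccc(-c3ccccc3)cc2)c2c1C=CC(C)(C)O2` reaches only a limit of this assay, > 10000 nM, not a number. Going by the values given here, the one step that can be stated, an at least 3.6-fold higher number from compound 2 to compound 3 (0.56 log units; beyond the scatter), shows that putting another group in place of the dimethylamino substituent costs potency, the resulting value sitting at the limit of > 10000 nM in this assay, at which 1 of the 3 values shown sits.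

Compound 4 `COc1ccc(C(=O)/C=C/c2cc(Cl)ccc2O)c2c1C=CC(C)(C)O2` is not yet measured. It differs from compound 2 by 5-chloro-2-hydroxyphenyl in place of 4-(dimethylamino)phenyl on a double-bonded chain carbon bound to a double-bonded chain carbon. The step from compound 2 to compound 3 bears on this change, since it too removes the dimethylamino group, and it was at least modest in the weakening direction. A weakening step beyond the scatter is therefore expected in this assay. Compound 4 is expected to give about 8000 nM, between 3000 nM and 20000 nM. This corresponds to an expected 2.9-fold higher number from compound 2 to compound 4 (0.46 log units; beyond the scatter).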

Compound 4, half-maximal inhibitory concentration: 6270 nM
The estimate for compound 4 lay 1.3-fold (0.11 log units) above the measured number; the range from low to high includes it.
By their numbers in this assay, from the lowest: compound 2; then compounds 4 and 1 (each within the scatter of the next). At a limit, above all of these: compound 3.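

Replacing the 4-(dimethylamino)phenyl group does not by itself take the result to a limit: 5-chloro-2-hydroxyphenyl, which brings a hydrogen-bond donor that the leaving group lacks, still gives a measured number in this assay, with a 2.3-fold higher number from compound 2 to compound 4 (0.36 log units; beyond the scatter). Compound 2 remains the lowest of the measured numbers, while compound 4 and compound 1 lie within the scatter of each other, so the 5-chloro-2-hydroxyphenyl and trimethoxyphenyl groups cannot be told apart here. Compound 3 still gives a limit and not a number: the limit of > 10000 nM in this assay, at which 1 of the 4 values shown sits.

The chlorine and the hydroxyl enter together in compound 4, so the compounds shown leave open what each contributes alone. They also leave open whether another amine at this place, such as 4-aminophenyl or 4-morpholinophenyl, would keep the number of compound 2.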